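A few compounds are considered here, and "the series" means these few. Any claim that something is new, unique, unknown or untested is made for them only; others in the source may bear on it.

Compound 1, with the structure `CC(C)(C)c1ccc(-c2cn(C/C=C3\OC(=O)C(OCc4ccccc4)=C3OCc3ccccc3)nn2)cc1`, was examined in an ADME assay on HEK293 cells (Homo sapiens) for cytotoxicity, read by MTT assay, with a stated time of 24 h; on this read-out lower numbers stand for stronger inhibition and higher numbers for weaker inhibition. In this assay compound 1 gives > 100000 nM, which is a limit of the assay and not a measured number. Two related compounds frame where it stands. Compound 2, `O=C1NC(O)(CCn2cc(-c3ccccc3)nn2)C(OCc2ccccc2)=C1OCc1ccccc1`, gives in this assay > 100000 nM, again a limit. Compound 3, `O=C1NC(O)(CCn2cc(Cc3ccccc3)nn2)C(OCc2ccccc2)=C1OCc1ccccc1`, gives in this assay 86000 nM, an actual number. Within the data shown here, the only measured step between compounds that differ in one place is an at least 1.1-fold lower number from compound 2 to compound 3 (0.06 log units; that floor lies within the scatter), a change that stays within the scatter of repeated measurements. Two of the three values sit at the limit of > 100000 nM in this assay, at which 2 of the 3 values shown sit, so the whole series shows weak cytotoxicity at best.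

Compound 4, `O=C1O/C(=C\Cn2cc(-c3ccccn3)nn2)C(OCc2ccccc2)=C1OCc1ccccc1`, differs from compound 1 in one place: pyridin-2-yl in place of 4-(tert-butyl)phenyl on an aromatic carbon. Among the measured compounds shown here, no measured step concerns this kind of exchange; the one measured step, from compound 2 to compound 3, touches a different part of the molecule and itself lies within the scatter. Because compound 1 gives > 100000 nM and because compound 2 gives > 100000 nM, weak cytotoxicity is expected to persist for compound 4, and the assay may well report only a limit again. Compound 4 is therefore estimated at 100000 nM, with a range from 50000 nM to 200000 nM. This estimate for compound 4 means an expected step of a number no higher from compound 1 to compound 4 (the limit leaves the size open), that is, none beyond the scatter.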

Compound 4, half-maximal inhibitory concentration: > 100000 nM
Compound 4: only a limit was reported (the forecaster's own chance of this, stated with the estimate: 70%); the middle value lies on the limit itself.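

Compound 1 and compound 4 each give only a limit of the assay in this assay, so the step between them cannot be read: the limit of > 100000 nM in this assay, at which 3 of the 4 values shown sit. The compounds shown leave open whether pyridin-2-yl in place of 4-(tert-butyl)phenyl changes the cytotoxicity at all, and where the true values of compound 1 and compound 4 lie.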